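The source may report more compounds than this note shows. Statements on the series, on what has been measured and on what is new or still open speak of the compounds shown alone.

Compound 1 `O=S(=O)(O)OCCCCCCCCCCCC[Se]c1ccccc1`, compound 2 `O=S(=O)(O)OCCCCCCCCCCC[Se]c1ccccc1` and compound 3 `O=S(=O)(O)OCCCCCCCC[Se]c1ccccc1` share one core and differ in the length of the saturated chain; how the cores of compound 3 and compound 2 differ is not broken down here. In a functional assay on RAW264.7 cells (Mus musculus) for cytotoxicity, read by MTT assay, with a stated time of 24 h (on this read-out lower numbers stand for stronger inhibition and higher numbers for weaker inhibition), compound 1 gives only a limit, > 100000 nM. Compound 2 likewise reaches only a limit, > 100000 nM. Compound 3 too stops at a limit, > 100000 nM. The change from compound 2 to compound 1, ((sulfooxy)methyl in place of sulfooxy on a saturated chain carbon, ten or more bonds along the chain from a selenium atom), gives a step that the two limits leave unreadable from compound 2 to compound 1, because all three values sit at the limit of > 100000 nM in this assay, at which 3 of the 3 values shown sit. Compound 4 `O=S(=O)(O)OCCCCCCCCC[Se]c1ccccc1` carries the same kind of change relative to compound 3, ((sulfooxy)methyl in place of sulfooxy on a saturated chain carbon, eight bonds along the chain from a selenium atom), the place differing only in how far along the chain from the selenium atom it lies. The step from compound 3 to compound 4 is expected to be a step that the limit leaves unreadable from compound 3 to compound 4, resting on (the limit of > 100000 nM in this assay, at which 3 of the 3 values shown sit), where compound 3 also stands. Compound 4 is therefore estimated at 150000 nM in this assay, most likely again reported only as a limit.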

Compound 4, half-maximal inhibitory concentration: > 100000 nM
Compound 4 ended at the assay's limit; the forecaster's own chance of this, stated with the estimate: 90%; the middle value lies beyond the limit too.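

No step can be read between compound 4 and compound 1, compound 2 or compound 3 in this assay, because all four stop at a limit: the limit of > 100000 nM in this assay, at which 4 of the 4 values shown sit. The compounds shown leave open whether chain length affects cytotoxicity at all.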